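Cytotoxicity limits and a carbamate-capped side chain

This account rests on a few compounds, and the source may have more. Where it says the series, first, only, none or still open, it means among the compounds named here.

In an ADME assay on BJ cells (Homo sapiens) for cytotoxicity, with a stated time of 72 h (on this read-out lower numbers stand for an effect already at smaller amounts and higher numbers for an effect only at larger amounts of compound), compound 1 `COc1ccc2ncnc(-n3nc(-c4ccccn4)nc3N)c2c1` gives only a limit (> 27000 nM). Compound 2 `COc1cc2nc(Cl)nc(-n3nc(-c4ccccn4)nc3N)c2cc1OC` also gives only a limit (> 13000 nM). Compound 3 `COc1cc2ncnc(-n3nc(-c4ccccn4)nc3N)c2cc1OCCCN(C)C` likewise stands at a limit (> 25000 nM), and the two other values are limits too.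

Compound 4 `COc1cc2ncnc(-n3nc(-c4ccccn4)nc3N)c2cc1OCCCCNC(=O)OC(C)(C)C` carries ((tert-butoxycarbonyl)amino)methyl in place of dimethylamino on a saturated chain carbon, three bonds along the chain from an oxygen on an aromatic ring.

No step beyond the usual scatter is expected in this assay, in either direction, given that compound 3 sits at a limit (> 25000 nM). The expected step is small (an at least 1.2-fold lower number from compound 3 to compound 4 (0.09 log units; that floor lies within the scatter)). Compound 4 is estimated at 20000 nM (expected range 8000 nM to 35000 nM).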

Compound 4, half-maximal effective concentration: > 7000 nM
Compound 4: a limit, no number; the forecaster's own chance of this, stated with the estimate: 75%; the middle value lies beyond the limit too.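

Among these compounds, compound 3 and compound 4 both stand at limits, so no step between them can be read. The compounds shown leave open at what concentration any of them would reach a half-maximal effect in this assay.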